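The source may hold more compounds than are shown below. What is called first, only, known or untested is meant among the compounds shown, and "the series" means these compounds.

Measured so far:
- Compound 1 `CCC(/C=C1\OC(=O)NC1=O)(CC)c1ccc(-c2ccc3cc(F)cc(F)c3c2)[nH]c1=O`: in an ADME assay on microsomes from liver (Homo sapiens) for metabolic stability (a higher number here means that the compound lasts longer, a lower number that the compound disappears faster), compound 1 gives > 3 h, which is a limit of this assay rather than a number.
- Compound 2 `CCC(/C=C1\OC(=O)NC1=O)(CC)c1ccc(-c2ccc3cccc(F)c3c2)[nH]c1=O`: compound 2 gives 0.948 h.

Among the measured compounds shown here, compound 2 thus holds the only plain number here; the other value sits at the limit of > 3 h in this assay, at which 1 of the 2 values shown sits. For the measured compounds named here, the single measured step, an at least 3.1-fold lower number from compound 1 to compound 2 (0.50 log units; beyond the scatter), came with hydrogen in place of fluoro on an aromatic carbon.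

Compound 3 `CCc1cccc2ccc(-c3ccc(C(/C=C4\OC(=O)NC4=O)(CC)CC)c(=O)[nH]3)cc12` differs from compound 2 by ethyl in place of fluoro on an aromatic carbon. Going by the values given here, no measured step swaps fluoro for ethyl, so the measured step offers only loose guidance; the change is expected to give a 1.6-fold lower number from compound 2 to compound 3 (0.20 log units; within the scatter), a drop not clearly beyond the scatter. Compound 3 is therefore estimated at 0.6 h, between 0.25 h and 1.5 h.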

Compound 3, half-life: 0.178 h
Compound 3: the middle estimate sits 3.4-fold (0.53 log units) above what was measured, and the stated range ends above it.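

Swapping the fluoro that compound 2 kept for ethyl gives a 5.3-fold lower number from compound 2 to compound 3 (0.73 log units; beyond the scatter) in this assay. So a second carbon of this ring, ortho to a fused ring, also affects how long the compound lasts, and the earlier step, which changed a different fluoro, could not show that. Nothing measured here explains why ethyl behaves this way.

The compounds shown leave open whether the size of the group matters at this carbon, and whether a methyl, a methoxy or an amine there would last as long as fluoro does in compound 2.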